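The compounds below may be only part of what the source reports. "The series", "measured", "known", "first", "only" and "open" are said of these compounds alone.

Measured in a functional assay on HCT-116 cells (Homo sapiens) for antiproliferative activity, read by MTT assay, with a stated time of 72 h; on this read-out higher numbers stand for weaker inhibition and lower numbers for stronger inhibition:
- compound 1 `CCC[C@H](NC(=O)N1C/C(=C\c2ccc(F)cc2)C(=O)/C(=C/c2ccc(F)cc2)C1)B1OC(C)(C)C(C)(C)O1`: 785 nM
- compound 2 `CC1(C)OB([C@@H](NC(=O)N2C/C(=C\c3ccc(F)cc3)C(=O)/C(=C/c3ccc(F)cc3)C2)C2CCCCC2)OC1(C)C`: 903 nM
- compound 3 `CC(C)C[C@H](NC(=O)N1CCN(C(=O)N2C/C(=C\c3ccc(F)cc3)C(=O)/C(=C/c3ccc(F)cc3)C2)CC1)B1OC(C)(C)C(C)(C)O1`: 1630 nM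

Compound 2, at 903 nM, stands within the scatter of both other measured compounds. Still unmeasured is compound 4 `CC[C@H](NC(=O)N1C/C(=C\c2ccc(F)cc2)C(=O)/C(=C/c2ccc(F)cc2)C1)B1OC(C)(C)C(C)(C)O1`, which differs from compound 2 in one place: ethyl in place of cyclohexyl on a saturated chain carbon bound to an amide-type nitrogen and a boron atom. It has ethyl in place of cyclohexyl on a saturated chain carbon bound to an amide-type nitrogen and a boron atom.

For the measured compounds named here, only one measured step bears on this change, and it concerns the same carbon: a 1.2-fold higher number from compound 1 to compound 2 (0.06 log units; within the scatter), with cyclohexyl in place of propyl. Going by the values given here, that step lies within the scatter, and no measured step links compound 3 to this change. A swap of ethyl for cyclohexyl is therefore expected to produce no shift beyond the scatter in this assay, although one small step is thin support. The expected change is a 1.1-fold lower number from compound 2 to compound 4 (0.04 log units; within the scatter), within the scatter. For compound 4 the estimated value is 820 nM, with an expected range from 400 nM to 1650 nM.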

Compound 4, half-maximal inhibitory concentration: 876 nM
Compound 4: the middle estimate sits 1.1-fold (0.03 log units) below what was measured, and the stated range covers the measured number.
By their numbers in this assay, from the lowest: compounds 1, 4, 2 and 3 (each within the scatter of the next, the first and the last beyond it).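

Until now, this position rested on a single step between propyl and cyclohexyl. In this assay, the change to ethyl on the saturated chain carbon bound to an amide-type nitrogen and a boron atom adds two further steps within the scatter: a 1.0-fold lower number from compound 2 to compound 4 (0.01 log units; within the scatter) and, on the side of the shorter chain, a 1.1-fold higher number from compound 1 to compound 4 (0.05 log units; within the scatter). Ethyl, propyl and cyclohexyl thus cannot be told apart at this carbon in this read-out, and nothing available bears on why the number stays put across these three groups.

The compounds shown leave open whether an amine or a carboxylic acid on this carbon would give a step beyond the scatter. They also leave open whether a phenyl ring or a much longer chain such as octyl would fit the same picture.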